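The source may hold more compounds than are shown below. What is called first, only, known or untested is meant among the compounds shown, and "the series" means these compounds.

Measured so far in an ADME assay on MT4 cells (Homo sapiens) for cytotoxicity; a lower number here means that less compound is tolerated, a higher number that more compound is tolerated:
compound 1, `O=C(CSc1snnc1-c1ccccc1)Nc1ccccc1F`, gives > 361000 nM.
compound 2, `O=C(CSc1snnc1-c1ccccc1)Nc1ccccc1Cl`, gives > 345000 nM.
compound 3, `O=C(CSc1snnc1-c1ccc(F)cc1F)Nc1ccccc1Cl`, gives 178000 nM.

The values for compound 1 and compound 2 are limits of this assay rather than numbers. The value for compound 1 is a limit. The value for compound 2 is likewise a limit. Compound 3 is the only one of the three that yields a number.

Compound 1 and compound 2 differ by fluoro in place of chloro on an aromatic carbon, and the step in this assay is a step that the two limits leave unreadable from compound 2 to compound 1, which cannot be read because of the limit of > 345000 nM in this assay, at which 1 of the 3 values shown sits, and (the limit of > 361000 nM in this assay, at which 1 of the 3 values shown sits). Compound 2 and compound 3 share the same core but differ by 2,4-difluorophenyl in place of phenyl on an aromatic carbon, giving an at least 1.9-fold lower number from compound 2 to compound 3 (0.28 log units; that floor lies within the scatter).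

Compound 4, `O=C(CSc1snnc1-c1ccc(F)cc1F)Nc1ccccc1F`, has not yet been measured. It differs from compound 3 by fluoro in place of chloro on an aromatic carbon, the same change made from compound 2 to compound 1. That earlier step gives no readable size, so the expectation for compound 4 rests on compound 3 alone: a step close to none, a 1.4-fold higher number from compound 3 to compound 4 (0.15 log units; within the scatter), is expected, with the understanding that this assay may again report only a limit. Compound 4 is expected to give about 250000 nM in this assay, estimated to lie between 120000 nM and 500000 nM.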

Compound 4, half-maximal cytotoxic concentration: 148000 nM
Estimate against measurement, compound 4: 1.7-fold (0.23 log units) above, within the range that was stated.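

In this assay, fluoro in place of chloro among the 2,4-difluorophenyl compounds gives a 1.2-fold lower number from compound 3 to compound 4 (0.08 log units; within the scatter), so this change leaves no readable mark on that core. Carrying 2,4-difluorophenyl in place of phenyl onto a second core gives an at least 2.4-fold lower number from compound 1 to compound 4 (0.38 log units; beyond the scatter), and the two cores can be set side by side only as floors: the same change on two cores in this assay, an at least 1.9-fold lower number (0.28 log units; that floor lies within the scatter) from compound 2 to compound 3 and an at least 2.4-fold lower number (0.38 log units; beyond the scatter) from compound 1 to compound 4; the limit leaves it open whether they differ The fluoro for chloro step on the core of compound 1 cannot be read, so it is not shown whether that change behaves alike on both cores, and since compound 1 and compound 2 both stand at limits of the assay, the true size of the 2,4-difluorophenyl step remains unknown on either core.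

On these data alone, all four compounds vary only by fluoro or chloro on the same shared core, so what an amine, a carboxylic acid or a methoxy group would do at these places in this assay stays open. As far as these compounds go, it is also open whether a longer chain between the two aromatic rings would change the picture, or whether halogens placed elsewhere on those rings would give the same steps.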